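The compounds below may be only part of what the source reports. "The series", "measured", "known", "first", "only" and "open" are said of these compounds alone.

Measured in a functional assay on MCF7 cells (Homo sapiens) for cytotoxicity, read by WST assay, with a stated time of 72 h; a higher number here means a weaker inhibitor, a lower number a stronger inhibitor:
- compound 1 `O=C1Nc2c(ccc(F)c2F)C1(c1ccc(O)cc1)C1CCCCC1`: 13 nM; 18 nM; > 1000 nM (3 entries)
- compound 2 `COc1ccc2c(c1C)NC(=O)C2(c1ccc(O)cc1)c1ccc(F)cc1`: 6.3 nM

Compound 1 has a limit among its entries, (the several entries of compound 1 in this assay, 13 nM; 18 nM; > 1000 nM (3 entries)). Compound 2 has one number, 6.3 nM, and a further entry gives no single number. Compound 3 `COc1ccc2c(c1C)NC(=O)C2(c1ccc(O)cc1)C1CCCCC1` has cyclohexyl in place of 4-fluorophenyl on a saturated ring carbon. Compound 1 also carries cyclohexyl and gives the numbers in the several entries of compound 1 in this assay, 13 nM; 18 nM; > 1000 nM (3 entries), so no change beyond the scatter of this assay is expected. The expected step is a 1.4-fold higher number from compound 2 to compound 3 (0.15 log units; within the scatter). For compound 3 the estimate is 9 nM, with an expected range from 2.5 nM to 40 nM.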

Compound 3, half-maximal inhibitory concentration: 14 nM
Compound 3: middle estimate off by 1.6-fold (0.19 log units), on the low side; the measured number falls inside the stated range.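

In this assay, replacing the aromatic 4-fluorophenyl with the non-aromatic cyclohexyl on the saturated ring carbon gives a 2.2-fold higher number from compound 2 to compound 3 (0.35 log units; beyond the scatter). This direct comparison shows that an aromatic ring at this position is not needed for activity in the nanomolar range, although the change does carry a modest cost. No measurement shown here bears on the cause of this step.

Going by these compounds, whether a smaller group such as methyl, or an amine, a carboxylic acid or a longer alkyl chain, would retain activity on this carbon remains open.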